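Urea aryl swap on the shared core

This account rests on a few compounds, and the source may have more. Where it says the series, first, only, none or still open, it means among the compounds named here.

Measured so far:
compound 1, `O=C(Nc1cccc(Cl)c1)Nc1cccc(CNc2nccnc2Cl)c1`: 6810 nM in a functional assay on T-24 cells (Homo sapiens) for antiproliferative activity, read by MTT assay, with a stated time of 48 h; on this read-out higher numbers stand for weaker inhibition and lower numbers for stronger inhibition
compound 2, `O=C(Nc1ccc(C(F)(F)F)cc1)Nc1cccc(CNc2nccnc2Cl)c1`: 4580 nM in this assay

Compound 1 stands at the highest number of the pair in this assay; its nearest neighbour is compound 2, whose value lies within the scatter of that of compound 1, so no order between them is claimed. Compound 3, `Cc1ccc(NC(=O)Nc2cccc(CNc3nccnc3Cl)c2)cc1C`, is not yet measured. It differs from compound 1 in one place: 3,4-dimethylphenyl in place of 3-chlorophenyl on an amide-type nitrogen. For the measured compounds named here, no step between measured compounds covers this change, and compound 2 carries a different group on that nitrogen, so its value gives no reading on the size of such a swap. The expected step is a 1.2-fold lower number from compound 1 to compound 3 (0.07 log units; within the scatter), nothing beyond the scatter and in no firm direction. Compound 3 is estimated at 5800 nM in this assay, with a range from 2500 nM to 13000 nM.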

Compound 3, half-maximal inhibitory concentration: 8930 nM
The estimate for compound 3 lay 1.5-fold (0.19 log units) below the measured number; low and high end bracket the measured number.
By their numbers in this assay, from the lowest: compounds 2, 1 and 3 (each within the scatter of the next).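

In this assay the swap of 3-chlorophenyl for 3,4-dimethylphenyl on an amide-type nitrogen gives a 1.3-fold higher number from compound 1 to compound 3 (0.12 log units; within the scatter) and so stays within the scatter. For the compounds shown here, this is the first step read at this position, and it shows that replacing a ring carrying chlorine with a ring of carbon only, one heavy atom larger, gives no separable change in this read-out. Nothing measured on these compounds offers an explanation for this result.

Still open, going by these compounds, is whether any group at this nitrogen can move the number beyond the scatter, for instance an aryl ring carrying an amine or a carboxylic acid, or a longer chain in place of the aryl ring. Also open, on these data alone, is whether changes to the shared core would do so.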